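Swapping the saturated ring of compound 1 for an aromatic one

The source may hold more compounds than are shown below. What is called first, only, known or untested is meant among the compounds shown, and "the series" means these compounds.

Compound 1 `CN(C)c1ccc(C(=O)Nc2cccc(NC(=O)COc3ccc4c(c3)NC(=O)CC4)c2)cc1` was tested in an assay on isolated protein for inhibition of Rho-associated protein kinase 1 (Homo sapiens), read by scintillation counting, radiometric assay and 33P incorporation, with a stated time of 40 min, in the presence of a further agent that is not named here; a higher number here means a weaker inhibitor, a lower number a stronger inhibitor. In this assay compound 1 gives only a limit, > 10000 nM, not a number, which is where the limit of > 10000 nM in this assay, at which 1 of the 2 values shown sits, sits. Compound 2 `COc1cc(OCC(=O)Nc2cccc(NC(=O)c3ccc(N(C)C)cc3)c2)ccc1C=O` shares the same core, and in this assay compound 2 gives 3740 nM; the change gave an at least 2.6-fold lower number from compound 1 to compound 2 (0.42 log units; beyond the scatter). Compound 3 `CN(C)c1ccc(C(=O)Nc2cccc(NC(=O)COc3ccc4occc(=O)c4c3)c2)cc1` is not yet measured, and its change from compound 1 is a group of 11 heavy atoms (9 carbon, 2 oxygen; one six-membered aromatic ring of carbon only, one six-membered aromatic ring with 1 hetero atom) in place of a group of 11 heavy atoms (9 carbon, 1 nitrogen, 1 oxygen; one six-membered non-aromatic ring with 1 hetero atom, one six-membered aromatic ring of carbon only), on an oxygen on a saturated carbon. Among the compounds with values here, only the step from compound 1 to compound 2 bears on it, and it shows that exchanging this group can move the number beyond the scatter. The new group in compound 3 is aromatic, unlike that in compound 2, so the direction is uncertain; a modest improvement is expected, an at least 1.6-fold lower number from compound 1 to compound 3 (0.22 log units; that floor lies within the scatter). Compound 3 is therefore estimated at 6000 nM, within a range of 1500 nM to 20000 nM.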

Compound 3, half-maximal inhibitory concentration: > 10000 nM
Compound 3: only a limit was reported; the forecaster's own chance of this, stated with the estimate: 40%; middle value at least 1.6-fold (0.22 log units) from the limit.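

Exchanging the group at this place, on an oxygen on a saturated carbon, gives an at least 2.6-fold higher number from compound 2 to compound 3 (0.42 log units; beyond the scatter). In this assay compound 3 gives only a limit, > 10000 nM, so replacing the non-aromatic ring of compound 1 with an aromatic one does not by itself bring the reading within the range of the assay, and compound 2 is the only one of the three with a number: the limit of > 10000 nM in this assay, at which 2 of the 3 values shown sit. The step between compound 1 and compound 3 cannot be read, as both values are limits.

On these data alone, it remains open whether the methoxy or the aldehyde on the ring of compound 2 matters more, as the two occur only together here. As far as these compounds go, how an amine or a carboxylic acid at this place would read also remains open.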